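From 4-iodophenyl to 3,4-dichlorophenyl in the series

The compounds below may be only part of what the source reports. "The series", "measured", "known", "first", "only" and "open" are said of these compounds alone.

Of the compounds shown here, two have been read so far in an ADME assay on MDBK cells (Bos taurus) for cytotoxicity; a higher number here means that more compound is tolerated, a lower number that less compound is tolerated. Compound 1 `Cc1cccc(Cn2ccc3nc(-c4ccccc4)nc-3c2)c1` gives only a limit, > 100000 nM. Within the data shown here, compound 2 `Ic1ccc(Cn2ccc3nc(-c4ccccc4)nc-3c2)cc1` gives 22000 nM, the only actual number and so the sole anchor for what follows.

Among the measured compounds shown here, the one measured step is an at least 4.5-fold lower number from compound 1 to compound 2 (0.65 log units; beyond the scatter), with 4-iodophenyl in place of 3-methylphenyl on a saturated chain carbon bound to an aromatic nitrogen. Compound 3 `Clc1ccc(Cn2ccc3nc(-c4ccccc4)nc-3c2)cc1Cl` changes the same place, with 3,4-dichlorophenyl in place of 4-iodophenyl (3,4-dichlorophenyl in place of 4-iodophenyl on a saturated chain carbon bound to an aromatic nitrogen). The measured step bears on this only indirectly, as it involves a different pair of groups and its size is open-ended. Like compound 2, compound 3 carries halogen on the phenyl ring, whereas compound 1 carries a methyl group, so no repeat of that step is expected. The expected change is a 1.1-fold higher number from compound 2 to compound 3 (0.06 log units; within the scatter), an estimate that stays within the scatter and points in no firm direction. For compound 3 the estimated value in this assay is 25000 nM, with an expected range of 9000 nM to 70000 nM.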

Compound 3, half-maximal cytotoxic concentration: 71000 nM
Estimate against measurement, compound 3: 2.8-fold (0.45 log units) below; the whole stated range lies below it.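

In this assay, the place on a saturated chain carbon bound to an aromatic nitrogen proves sensitive to more than the presence of halogen on the phenyl ring: 3,4-dichlorophenyl and 4-iodophenyl do not read alike (a 3.2-fold higher number from compound 2 to compound 3 (0.51 log units; beyond the scatter)). Set against 3-methylphenyl, the 3,4-dichlorophenyl group gives only an open-ended comparison (an at least 1.4-fold lower number from compound 1 to compound 3 (0.14 log units; that floor lies within the scatter)), so no order between these two groups can be claimed from this pair. The value for compound 1 remains a limit of the assay and not a number, and this bounds what the series can show at its upper end: (the limit of > 100000 nM in this assay, at which 1 of the 3 values shown sits).

The step from 4-iodophenyl to 3,4-dichlorophenyl changes the halogen and the number of halogens together, so the compounds shown do not tell which of the two goes with the higher number. Also open, from the compounds shown here alone, is how the series reads with a single chlorine on the phenyl ring, or with an amine or a carboxylic acid there, and whether any such group would bring the number closer to the limit or further from it.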